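The compounds below may be only part of what the source reports. "The series", "measured", "known", "first", "only" and "open" are said of these compounds alone.

Series notes, inhibition of cell growth

Measured compounds:
- compound 1, `O=C(Nc1cccc(-n2cc(-c3ccncc3)c(-c3cc(O)cc(Cl)c3)n2)c1)Nc1ccc(Cl)c(Cl)c1`, in a functional assay on NCI/ADR-RES cells (Homo sapiens) for inhibition, read by sulforhodamine B assay, with a stated time of 48 h, tested at 0.01 uM (on this read-out lower numbers stand for a stronger effect and higher numbers for a weaker effect at the one concentration tested), compound 1 gives 109%
- compound 2, `COc1cc(Cl)cc(-c2nn(-c3cccc(NC(=O)Nc4ccc(Cl)c(C(F)(F)F)c4)c3)cc2-c2ccncc2)c1`, compound 2 gives 98%
- compound 3, `COc1cc(Cl)cc(-c2nn(-c3cccc(NC(=O)Nc4cc(C(F)(F)F)cc(C(F)(F)F)c4)c3)cc2-c2ccncc2)c1`, compound 3 gives 99%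

All three numbers sit close to full growth at the single concentration tested, so none of the compounds shows a clear effect under these conditions. Compound 3 falls between the other two: its nearest neighbour is compound 2, whose number lies within the scatter of it, and the furthest is compound 1, whose number is also within the scatter. Across the three measured compounds, therefore, no difference in read-out can be claimed; the urea substituent pattern varies (two chlorines, chlorine plus trifluoromethyl, two trifluoromethyls) without any number moving beyond the scatter.

Compound 4, `COc1cc(Cl)cc(-c2nn(-c3cccc(NC(=O)Nc4cccc(C(F)(F)F)c4)c3)cc2-c2ccncc2)c1`, has not been measured. It differs from compound 3 by hydrogen in place of trifluoromethyl on an aromatic carbon.

Within the data shown here, no step between measured compounds is available for this change. Given that compounds 1, 2 and 3 all read near the same value, the step from compound 3 to compound 4 is expected to be none beyond the scatter, estimated as a number 1 percentage points higher from compound 3 to compound 4 (within the scatter). Compound 4 is therefore expected to give about 100% in this assay, within a range of 88% to 112%.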

Compound 4, a percentage reported as activity, at one concentration (the size of the read-out at that concentration, not a potency): 100%
The estimate for compound 4 equals the measured number at the digits printed; low and high end bracket the measured number.
By their numbers in this assay, from the lowest: compounds 2, 3, 4 and 1 (each within the scatter of the next, the first and the last beyond it).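

Among these compounds, these are the first single-place steps, and both are small: in this assay, hydrogen in place of trifluoromethyl on an aromatic carbon, meta to a trifluoromethyl group, gives a number 1 percentage points higher from compound 3 to compound 4 (within the scatter), and hydrogen in place of chloro on an aromatic carbon gives a number 2 percentage points higher from compound 2 to compound 4 (within the scatter). The earlier compounds shown here varied the substituents on this ring only as chlorine and trifluoromethyl pairs, whereas these steps compare a substituent directly with plain hydrogen, and at this single concentration neither exchange separates the compounds. Among the compounds shown here, since all of these read close to full growth, the steps show only that neither exchange brings out an effect under these conditions, and no measured information is available to explain that result.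

Going by these compounds, it remains open whether either exchange would separate the compounds at a concentration where the series shows a clear effect, as a flat read-out gives little basis for ranking substituents. Also open, on these data alone, is whether a more different group at this aromatic carbon, such as an amine, a carboxylic acid or a longer chain, would give a step beyond the scatter.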